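Thiophene carboxamide thioureas: ortho-methoxy swap for ortho-chloro

A few compounds are considered here, and "the series" means these few. Any claim that something is new, unique, unknown or untested is made for them only; others in the source may bear on it.

Measured so far in a functional assay on HeLa cells (Homo sapiens) for antiproliferative activity, with a stated time of 24 h; on this read-out higher numbers stand for weaker inhibition and lower numbers for stronger inhibition:
Compound 1, `NC(=O)c1c(NC(=O)c2ccccc2)sc2c1CCN(C(=S)Nc1ccccc1Cl)C2`: compound 1 gives > 50000 nM, a limit of the assay.
Compound 2, `COc1ccccc1C(=O)Nc1sc2c(c1C(N)=O)CCN(C(=S)Nc1ccccc1Cl)C2`: compound 2 gives > 50000 nM, a limit of the assay.
Compound 3, `NC(=O)c1c(NC(=O)c2ccncn2)sc2c1CCN(C(=S)Nc1ccccc1Cl)C2`: compound 3 gives > 50000 nM, a limit of the assay.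

Compound 2 thus stands at the limit, as do the two other measured values; see (the limit of > 50000 nM in this assay, at which 3 of the 3 values shown sit). The steps between the measured compounds, a step that the two limits leave unreadable from compound 1 to compound 2, a step that the two limits leave unreadable from compound 1 to compound 3 and a step that the two limits leave unreadable from compound 2 to compound 3, are all unreadable because the limit of > 50000 nM in this assay, at which 3 of the 3 values shown sit, holds for both ends of each.

Compound 4, `COc1ccccc1NC(=S)N1CCc2c(sc(NC(=O)c3ccccc3OC)c2C(N)=O)C1`, is not yet measured. Relative to compound 2 the change is methoxy in place of chloro on an aromatic carbon. Among the measured compounds shown here, none of the measured steps involves the thiourea-bound aryl group, so none bears directly on this change; all that is known is that compound 2 and its two neighbours give only the limit. On that basis no step beyond the scatter is expected, and compound 4 is expected to sit again at the limit, a step that the limit leaves unreadable from compound 2 to compound 4. The estimate for compound 4 is 80000 nM, within 30000 nM to 300000 nM.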

Compound 4, half-maximal inhibitory concentration: > 50000 nM
Compound 4: no number, only a limit; the forecaster's own chance of this, stated with the estimate: 85%; the middle value does not contradict the limit.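

In this assay, among the compounds shown here, compound 4 gives > 50000 nM, a limit of the assay, and no step from compound 2 to compound 4 can be read: the limit of > 50000 nM in this assay, at which 4 of the 4 values shown sit. Left open is whether methoxy or chloro on this aromatic ring makes any difference, and whether any of these compounds has a measurable value in this assay.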